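The source may hold more compounds than are shown below. What is called first, only, known or untested is meant among the compounds shown, and "the series" means these compounds.

Compound 1 `COc1ccc(-c2cncc3[nH]c(=O)n(Cc4cc(OC)c(OC)c(OC)c4)c23)cc1`: > 20000 nM, a limit
Compound 2 `COc1ccc(-c2nc3cnccc3n2-c2cc(OC)c(OC)c(OC)c2)cc1O`: > 20000 nM, a limit
Compound 3 `COc1ccc(-c2cc3c(cn2)[nH]c(=O)n3-c2cc(OC)c(OC)c(OC)c2)cc1F`: 2210 nM

Going by the values given here, in a functional assay on HeLa cells (Homo sapiens) for antiproliferative activity, read by MTT assay, with a stated time of 48 h (on this read-out higher numbers stand for weaker inhibition and lower numbers for stronger inhibition), compound 3 is the only compound with a number, 2210 nM. The entries for compound 1 and compound 2 are limits, not numbers.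

Next is compound 4 `CCOc1ccc(-c2cc3c(cn2)[nH]c(=O)n3-c2cc(OC)c(OC)c(OC)c2)cc1`, with the change 4-ethoxyphenyl in place of 3-fluoro-4-methoxyphenyl on an aromatic carbon. Compound 1 and compound 2 differ from compound 3 in more than one place, so neither gives a measure of this change. In this assay, no step beyond the scatter is expected. The expected change is a 1.4-fold higher number from compound 3 to compound 4 (0.13 log units; within the scatter). The estimate for compound 4 is 3000 nM, with an expected range of 600 nM to 15000 nM.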

Compound 4, half-maximal inhibitory concentration: 3730 nM
Estimate against measurement, compound 4: 1.2-fold (0.09 log units) below; measured number inside the range.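

In this assay, going by these compounds alone, this is the first comparison that differs in one place: on the aromatic carbon next to the ring nitrogen, 4-ethoxyphenyl in place of 3-fluoro-4-methoxyphenyl gives a 1.7-fold higher number from compound 3 to compound 4 (0.23 log units; within the scatter). This position therefore holds either group without a step beyond the scatter. The loss of the fluorine and the change from methoxy to ethoxy occur together, so they cannot be read apart.

As far as these compounds go, whether an amine or a carboxylic acid on this phenyl ring would shift the number remains open. The entries for compound 1 and compound 2 are limits, and no steps to them can be read: the limit of > 20000 nM in this assay, at which 2 of the 4 values shown sit.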